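Nitro for Fluoro on the Shared Core: An Expectation

This account rests on a few compounds, and the source may have more. Where it says the series, first, only, none or still open, it means among the compounds named here.

Measured compounds:
compound 1 `O=c1ccoc2cc(OCc3cn(Cc4cccc(F)c4)nn3)ccc12` — > 100000 nM
compound 2 `C#CCOc1ccc2c(=O)ccoc2c1` — > 100000 nM

Compound 1 stands at a limit rather than at a number. In a functional assay on SGC-7901 cells (Homo sapiens) for cytotoxicity, read by MTT assay, with a stated time of 48 h (on this read-out lower numbers stand for stronger inhibition and higher numbers for weaker inhibition), compound 1 gives > 100000 nM, which is a limit of the assay. Compound 2 likewise gives > 100000 nM in this assay, again a limit. Both values sit at the limit of > 100000 nM in this assay, at which 2 of the 2 values shown sit, so neither compound shows measurable inhibition here.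

Compound 3 `O=c1ccoc2cc(OCc3cn(Cc4cccc([N+](=O)[O-])c4)nn3)ccc12` differs from compound 1 by nitro in place of fluoro on an aromatic carbon; cut one bond further out, the change reads 3-fluorophenyl to 3-nitrophenyl. For the measured compounds named here, no step between measured compounds exists to weigh this change against, and both measured values are limits. In this assay no step beyond the scatter is expected in either direction, and compound 3 is expected to remain at the limit.

Compound 3 is estimated at 150000 nM, between 60000 nM and 500000 nM. The expected step amounts to a step that the limit leaves unreadable from compound 1 to compound 3.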

Compound 3, half-maximal inhibitory concentration: > 100000 nM
Compound 3 was reported as a limit; the forecaster's own chance of this, stated with the estimate: 80%; the middle value lies beyond the limit too.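

In this assay compound 3 gives > 100000 nM, which is a limit. No step can be read between compound 1 and compound 3: the limit of > 100000 nM in this assay, at which 3 of the 3 values shown sit. The compounds shown leave open whether any change on the shared core would give a measurable value in this assay.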